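The compounds below may be only part of what the source reports. "The series", "measured", "known", "first", "only" and "open" are said of these compounds alone.

Compound 1, `CCCCC(O)c1cccc(NC(=O)NCCCCl)c1`, is the reference point. In a functional assay on MCF7 cells (Homo sapiens) for antiproliferative activity, with a stated time of 48 h (a lower number here means a stronger inhibitor, a higher number a weaker inhibitor), compound 1 gives only a limit, > 100000 nM. Compound 2, `CCCCC(OC)c1cccc(NC(=O)NCCCCl)c1`, differs from it by methyl in place of hydrogen on an oxygen on a saturated carbon, and in this assay compound 2 gives 50000 nM; the step is an at least 2.0-fold lower number from compound 1 to compound 2 (0.30 log units; that floor lies within the scatter). Compound 3, `C=CC(=O)Nc1cccc(C(O)CCCC)c1`, carries a different core than compound 1, the difference being (vinyl in place of (3-chloropropyl)amino on a carbonyl carbon). For compound 3, this assay again returns a limit, > 100000 nM. The step that the two limits leave unreadable from compound 1 to compound 3 cannot be sized, because compound 1 and compound 3 both sit at the limit of > 100000 nM in this assay, at which 2 of the 3 values shown sit. Compound 4, `C=CC(=O)Nc1cccc(C(CCCC)OC)c1`, has not yet been measured; it stands to compound 3 as compound 2 stands to compound 1, with methyl in place of hydrogen on an oxygen on a saturated carbon at the very same place. Resting on the step of an at least 2.0-fold lower number from compound 1 to compound 2 (0.30 log units; that floor lies within the scatter), the estimated step is an at least 1.2-fold lower number from compound 3 to compound 4 (0.09 log units; that floor lies within the scatter). Compound 4 is therefore expected to give about 80000 nM, estimated to lie between 30000 nM and 200000 nM, with a real chance of another limit.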

Compound 4, half-maximal inhibitory concentration: > 100000 nM
Compound 4: no number, only a limit; the forecaster's own chance of this, stated with the estimate: 55%; at least 1.2-fold (0.09 log units) between middle value and limit.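

In this assay compound 4 gives > 100000 nM, which is a limit of the assay and not a number. The steps from compound 1 to compound 3 and from compound 3 to compound 4 cannot be read, because each pair sits at the same limit: the limit of > 100000 nM in this assay, at which 3 of the 4 values shown sit.

The steps that can be read are an at least 2.0-fold lower number from compound 1 to compound 2 (0.30 log units; that floor lies within the scatter) and an at least 2.0-fold higher number from compound 2 to compound 4 (0.30 log units; that floor lies within the scatter), so the change from hydroxy to methoxy is shown neither to carry over to the core of compound 3 nor to fail there. Going by these compounds, whether an ethoxy group or an amine in place of the methoxy would give the core of compound 3 a readable value stays open. On these data alone, how far compound 1 and compound 3 truly lie from each other also stays open.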